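A few compounds are considered here, and "the series" means these few. Any claim that something is new, unique, unknown or untested is made for them only; others in the source may bear on it.

Measured so far:

Compound 1, `Fc1ccc2[nH]c(-c3cn(-c4ccccc4)nc3-c3ccc(Cl)cc3)nc2c1`, 2770 nM
Compound 2, `Clc1ccc(-c2nn(-c3ccccc3)cc2-c2nc3cc(Cl)ccc3[nH]2)cc1`, 1630 nM
Compound 3, `COc1ccc2[nH]c(-c3cn(-c4ccccc4)nc3-c3ccc(Cl)cc3)nc2c1`, 3630 nM

Of the compounds shown here, three sharing one core have been tested in a functional assay on HeLa cells (Homo sapiens) for antiproliferative activity, read by MTT assay, with a stated time of 48 h; a lower number here means a stronger inhibitor, a higher number a weaker inhibitor. Compound 2 and compound 3 differ by a single change, (methoxy in place of chloro on an aromatic carbon), and this gave a 2.2-fold higher number from compound 2 to compound 3 (0.35 log units; beyond the scatter). Compound 1 carries a different halogen on the same core; the difference from compound 2 is fluoro in place of chloro on an aromatic carbon, and the step of a 1.7-fold lower number from compound 1 to compound 2 (0.23 log units; within the scatter), while a 1.3-fold higher number from compound 1 to compound 3 (0.12 log units; within the scatter), so compound 1 and compound 3 sit together within the usual variation of the measurement.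

Compound 4, `COc1ccc(-c2nn(-c3ccccc3)cc2-c2nc3cc(F)ccc3[nH]2)cc1`, has not yet been measured. It differs from compound 1 by methoxy in place of chloro on an aromatic carbon. Among the measured compounds shown here, this is the same kind of change as the one between compound 2 and compound 3, but not the same: there the exchange sat on an aromatic carbon of a six-membered aromatic ring of carbon only, part of a fused or bridged system of two rings, meta to a fused ring and para to a fused ring, whereas here it sits on a six-membered aromatic ring of carbon only, para to a large group. Because a 2.2-fold higher number from compound 2 to compound 3 (0.35 log units; beyond the scatter), the expected step from compound 1 is a 1.8-fold higher number from compound 1 to compound 4 (0.26 log units; within the scatter), with wider uncertainty since the place is not the same. For compound 4 in this assay the estimate is 5000 nM, likely between 2000 nM and 12000 nM.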

Compound 4, half-maximal inhibitory concentration: 1740 nM
Beside the measured number, compound 4's estimate is 2.9-fold (0.46 log units) above it; measured number below the stated range.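

In this assay, replacing the 4-chlorophenyl of the core of compound 1 with 4-methoxyphenyl gave a 1.6-fold lower number from compound 1 to compound 4 (0.20 log units; within the scatter), so on this evidence the exchange leaves the reading essentially unmoved at this place. Methoxy in place of chloro therefore cannot be treated as a step of fixed size that carries from one core to another in this series, as the two available cases do not agree: the same change on two cores in this assay, a 2.2-fold higher number (0.35 log units; beyond the scatter) from compound 2 to compound 3 and a 1.6-fold lower number (0.20 log units; within the scatter) from compound 1 to compound 4, 3.5-fold (0.55 log units) apart, beyond the scatter of two such steps What this does not show is why they differ, since the exchange sits at a different place in each pair and only one pair stands for each place, so the effect of the place cannot be separated from that of the rest of the molecule, and two pairs give no general rule for the series.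

The compounds shown leave open whether the exchange on the 4-chlorophenyl would give a similar result with chloro or methoxy instead of fluoro on the other part of the shared core. They also leave open how an amine, a carboxylic acid or a longer alkoxy chain would read at either place.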